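Aryl swap on the shared core: fluorophenyl to thiophene

The compounds below may be only part of what the source reports. "The series", "measured", "known", "first", "only" and "open" are said of these compounds alone.

Measured so far:
compound 1 `COc1cc(C(C2=C(O)C(=O)c3ccccc3C2=O)c2c[nH]c3ccc(Br)cc23)cc(OC)c1OC` — 13000 nM
compound 2 `O=C1C(O)=C(C(c2ccc(F)cc2)c2c[nH]c3ccccc23)C(=O)c2ccccc21` — 28100 nM

In a functional assay on ECa-109 cells (Homo sapiens) for cytotoxicity, read by MTT assay, with a stated time of 48 h (on this read-out lower numbers stand for stronger inhibition and higher numbers for weaker inhibition), compound 2 gives 28100 nM, the higher of the two numbers; compound 1 gives 13000 nM, a lower number beyond the scatter. Compound 3 `O=C1C(O)=C(C(c2cccs2)c2c[nH]c3ccccc23)C(=O)c2ccccc21` differs from compound 2 by thiophen-2-yl in place of 4-fluorophenyl on a saturated chain carbon bound to an aromatic carbon and a double-bonded ring carbon. Among the compounds with values here, no step between measured compounds is known, so there is nothing to scale this change against. The expectation for a 1.1-fold lower number from compound 2 to compound 3 (0.05 log units; within the scatter) is no step beyond the scatter. Compound 3 is estimated at 25000 nM in this assay, with a range from 8000 nM to 80000 nM.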

Compound 3, half-maximal inhibitory concentration: 12100 nM
The estimate for compound 3 lay 2.1-fold (0.32 log units) above the measured number; the measured number falls inside the stated range.
By their numbers in this assay, from the lowest: compounds 3 and 1 (each within the scatter of the next); then compound 2.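

In this assay, within the data shown here, thiophen-2-yl in place of 4-fluorophenyl on a saturated chain carbon gives a 2.3-fold lower number from compound 2 to compound 3 (0.37 log units; beyond the scatter), the only step so far that can be read. The position therefore responds to an aryl swap, though the step is modest. Nothing at hand bears on the reason for this step.

As far as these compounds go, whether a furan-2-yl or cyclohexyl group at this carbon would give a similar number remains open. So does the outcome of an amine on the thiophen-2-yl ring.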